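Compound 3: a phenyl-bearing ring replaces trifluoromethyl

This account rests on a few compounds, and the source may have more. Where it says the series, first, only, none or still open, it means among the compounds named here.

Of the compounds shown here, two on a shared core have been measured in a toxicity assay on HepG2 2.2.15 cells (Homo sapiens) for cytotoxicity, read by CellTiter-Glo; on this read-out lower numbers stand for higher toxicity in this test and higher numbers for lower toxicity in this test. Compound 1 `O=C1OC(c2ccccc2)CN1c1cnn2c1CN(C(=O)Nc1cc(F)c(F)c(F)c1)C(C1CC1)C2` gives 7410 nM, while compound 2 `O=C1CC(C(F)(F)F)CN1c1cnn2c1CN(C(=O)Nc1cc(F)c(F)c(F)c1)C(C1CC1)C2` gives 115000 nM, the higher of the two numbers. Among the measured compounds shown here, the one measured step is a 16-fold higher number from compound 1 to compound 2 (1.19 log units; beyond the scatter), and it exchanges 2-oxo-5-phenyl-1,3-oxazolidin-3-yl for 2-oxo-4-(trifluoromethyl)pyrrolidin-1-yl.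

Compound 3 `O=C1NC(c2ccccc2)CN1c1cnn2c1CN(C(=O)Nc1cc(F)c(F)c(F)c1)C(C1CC1)C2` differs from compound 2 by having 2-oxo-4-phenylimidazolidin-1-yl in place of 2-oxo-4-(trifluoromethyl)pyrrolidin-1-yl on an aromatic carbon. The entering group carries a phenyl ring, as the group in compound 1 does, but its five-membered ring is a different one, so compound 1 is only a partial guide. For the measured compounds named here, that single step of a 16-fold higher number from compound 1 to compound 2 (1.19 log units; beyond the scatter) is all the evidence available, and no measured compound carries the entering group itself. Most of that step, though not all of it, is expected to be reversed in this assay. The expected change is a 7.7-fold lower number from compound 2 to compound 3 (0.88 log units; beyond the scatter). For compound 3 the estimate is 15000 nM, with an expected range of 4000 nM to 55000 nM.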

Compound 3, half-maximal cytotoxic concentration: 38500 nM
Estimate against measurement, compound 3: 2.6-fold (0.41 log units) below; the measured number falls inside the stated range.
By their numbers in this assay, from the lowest: compound 1; then compound 3; then compound 2.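

In this assay, swapping 2-oxo-4-(trifluoromethyl)pyrrolidin-1-yl for 2-oxo-4-phenylimidazolidin-1-yl on this aromatic carbon gives a 3.0-fold lower number from compound 2 to compound 3 (0.48 log units; beyond the scatter) and so shows that a phenyl-bearing ring can lower the number here, though compound 3 still stays above compound 1. The step between the two phenyl-bearing groups, a 5.2-fold higher number from compound 1 to compound 3 (0.72 log units; beyond the scatter) for 2-oxo-4-phenylimidazolidin-1-yl in place of 2-oxo-5-phenyl-1,3-oxazolidin-3-yl, shows that a phenyl ring alone does not fix the number at this position, since the ring carrying it also counts. No measurement bearing on the reason for either step is available.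

The compounds shown leave open how much of the gap between the two phenyl-bearing groups belongs to the ring hetero atom and how much to where the phenyl sits, as these two groups differ in both. They also leave open whether the phenyl ring itself accounts for the lower number, which a methyl group in its place on the imidazolidine ring, or 2-oxo-4-phenylpyrrolidin-1-yl as the matching partner of the group in compound 2, would help to separate.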